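Phenyl to Methyl on Two Cores

The compounds below may be only part of what the source reports. "The series", "measured", "known", "first", "only" and "open" are said of these compounds alone.

Measured compounds:
compound 1, `Cc1cc2c(c(N)nn2C)c(=O)[nH]1`, 11%
compound 2, `Cn1nc(N)c2c(=O)[nH]c(-c3ccccc3)cc21`, 8%
compound 3, `Cc1cc2nc(-c3ccccc3)nc(N)c2c(=O)[nH]1`, 7%

All three were tested in an assay on isolated protein for inhibition of RAC-alpha serine/threonine-protein kinase (Homo sapiens), read by mobility shift assay, tested at 30 uM; on this read-out lower numbers stand for less inhibition and higher numbers for more inhibition at the one concentration tested (going by the name of the read-out). In this assay compound 1 gives 11%, compound 2 gives 8% and compound 3 gives 7%. The change methyl in place of phenyl on an aromatic carbon gave a number 3 percentage points higher from compound 2 to compound 1 (within the scatter). The difference between the cores of compound 2 and compound 3 is not broken down here. Compound 4, `Cc1nc(N)c2c(=O)[nH]c(C)cc2n1`, carries the same kind of change, (methyl in place of phenyl on an aromatic carbon), but in compound 4 the place is on a ring with 2 nitrogen, between two ring nitrogen atoms and meta to an amino group, whereas in compound 1 it is on a ring with 1 nitrogen, next to the ring nitrogen. Because compound 2 to compound 1 gave a number 3 percentage points higher from compound 2 to compound 1 (within the scatter), the step from compound 3 to compound 4 is expected to be a number 2 percentage points higher from compound 3 to compound 4 (within the scatter). Compound 4 is estimated at 9%, likely between 0% and 19%.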

Compound 4, a percentage reported as inhibition, at one concentration (the size of the read-out at that concentration, not a potency): -2%
Compound 4: middle estimate off by 11 percentage points, on the high side, and the stated range ends above it.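

In this assay, methyl in place of phenyl on an aromatic carbon gave a number 9 percentage points lower from compound 3 to compound 4 (within the scatter), so neither this step nor the earlier one stands clear of the usual scatter. Set side by side, the two steps do not separate the cores: the same change on two cores in this assay, a number 3 percentage points higher (within the scatter) from compound 2 to compound 1 and a number 9 percentage points lower (within the scatter) from compound 3 to compound 4, 12 percentage points apart, within the scatter of two such steps. This shows no difference in how the change behaves on the two cores, but it does not show that the change carries over with the same size or direction, and neither step can be read as a real effect of the change.

The compounds shown leave open whether a group other than phenyl or methyl at this place, such as a carboxylic acid, a morpholine or a longer chain, would give a clearer step on either core.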